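The compounds below may be only part of what the source reports. "The series", "measured", "known", "first", "only" and "open" are said of these compounds alone.

The three measured compounds in a functional assay on L1210 cells (Mus musculus) for inhibition (on this read-out lower numbers stand for stronger inhibition and higher numbers for weaker inhibition), are compound 1 `O=C1/C(=C/c2ccc(F)cc2)Cc2ccccc21` with 89000 nM, compound 2 `Cc1ccc(/C=C2\Cc3ccccc3C2=O)cc1` with 59100 nM, and compound 3 `O=C1/C(=C/c2cccc(F)c2)CCc2ccccc21` with 61200 nM.

Compound 2 differs from compound 1 by methyl in place of fluoro on an aromatic carbon, and in this assay that step came to a 1.5-fold lower number from compound 1 to compound 2 (0.18 log units; within the scatter). Compound 3 rests on a different core than compound 1; the difference between the two cores is not broken down here. Compound 4 `Cc1cccc(/C=C2\CCc3ccccc3C2=O)c1` differs from compound 3 by methyl in place of fluoro on an aromatic carbon. This is the same kind of change as from compound 1 to compound 2, though in compound 4 the methyl sits meta to a large group where in compound 2 it sits para to a large group. Because the earlier step of a 1.5-fold lower number from compound 1 to compound 2 (0.18 log units; within the scatter) stayed within the scatter, the step of a 1.3-fold lower number from compound 3 to compound 4 (0.11 log units; within the scatter) is expected to be small as well. For compound 4 the estimate in this assay is 48000 nM, expected between 20000 nM and 120000 nM.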

Compound 4, half-maximal inhibitory concentration: 73200 nM
Estimate against measurement, compound 4: 1.5-fold (0.18 log units) below, and the stated range covers the measured number.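

In this assay, methyl in place of fluoro gave a 1.2-fold higher number from compound 3 to compound 4 (0.08 log units; within the scatter) on the core of compound 3. Set beside the same change on the core of compound 1, this step does not stand apart: the same change on two cores in this assay, a 1.5-fold lower number (0.18 log units; within the scatter) from compound 1 to compound 2 and a 1.2-fold higher number (0.08 log units; within the scatter) from compound 3 to compound 4, 1.8-fold (0.26 log units) apart, within the scatter of two such steps. On these two cores, then, the change stays small, but two pairs cannot show that it would stay small on any other core, and the group also sits at a different place on the ring in each pair.

The compounds shown carry only fluoro or methyl on this ring. On these data alone, how an amine, a carboxylic acid or a longer chain would read there in this assay remains open.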